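Methyl in Place of Hydrogen: Estimating Compound 3

The compounds below may be only part of what the source reports. "The series", "measured", "known", "first", "only" and "open" are said of these compounds alone.

Compound 1 `COC(=O)[C@@]1(C)CCC=C2[C@@H]1CC[C@@H](C)[C@]2(C)Cc1c[nH]c2ccc(F)cc12`: 7300 nM
Compound 2 `COC(=O)[C@@]1(C)CCC=C2[C@@H]1CC[C@@H](C)[C@]2(C)Cc1c[nH]c2ccc(C(F)(F)F)cc12`: 14000 nM

Both numbers come from a functional assay on SW1573 cells (Homo sapiens) for inhibition, read by sulforhodamine B assay, with a stated time of 48 h; a higher number here means a weaker inhibitor of growth, a lower number a stronger inhibitor of growth. Within the data shown here, compound 2 stands at the higher of the two numbers, and its only neighbour is compound 1; the step of a 1.9-fold higher number from compound 1 to compound 2 (0.28 log units; within the scatter) lies within the scatter, so the two compounds cannot be told apart on these numbers. Compound 3 `COC(=O)[C@@]1(C)CCC=C2[C@@H]1CC[C@@H](C)[C@]2(C)Cc1c(C)[nH]c2ccc(C(F)(F)F)cc12` has not yet been measured. It differs from compound 2 in one place: methyl in place of hydrogen on an aromatic carbon. Among the measured compounds shown here, no measured step bears on this change; the single step in hand, a 1.9-fold higher number from compound 1 to compound 2 (0.28 log units; within the scatter), concerns trifluoromethyl in place of fluoro and says nothing about a methyl group at this place. With nothing to lean on, the expectation for this assay is no step beyond the scatter, no change at the digits printed from compound 2 to compound 3 (within the scatter). Compound 3 is therefore expected to give about 14000 nM, with a range from 5000 nM to 40000 nM.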

Compound 3, concentration for 50% growth inhibition: 15000 nM
Estimate against measurement, compound 3: 1.1-fold (0.03 log units) below; measured number inside the range.
By their numbers in this assay, from the lowest: compounds 1, 2 and 3 (each within the scatter of the next, the first and the last beyond it).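

In this assay, methyl in place of hydrogen on this aromatic carbon, next to the ring nitrogen and next to the ring atom that bears a large group, gives a 1.1-fold higher number from compound 2 to compound 3 (0.03 log units; within the scatter), so compound 2 and compound 3 cannot be told apart. Among these compounds, this is the first measured change at this position, since the earlier step concerned only trifluoromethyl in place of fluoro, and it shows that one added methyl here leaves the growth-inhibition number within the scatter. Nothing available explains this result.

On these data alone, it remains open whether a longer chain such as ethyl, or a group such as an amine or a carboxylic acid, would behave the same way at this carbon. Also open, as far as these compounds go, is whether methyl here would give a similarly small step with fluoro in place of trifluoromethyl.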